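The source may hold more compounds than are shown below. What is called first, only, known or untested is meant among the compounds shown, and "the series" means these compounds.

Working notes on the series.

Compound 2, `CC(=O)N[C@@H](CO)C(=O)N[C@@H](C)C(=O)N[C@H](C(=O)N[C@@H](CC(C)C)C(=O)N[C@H](C=O)CC(C)C)C(C)C`, carries an isobutyl group on the carbon bearing the formyl group at the chain end. Within the data shown here, in an assay for inhibition of chymotrypsin-like protease CTRL-1 variant R188I (Homo sapiens), read by HPLC, with stated times of 20 min and 60 min (a lower number here means a stronger inhibitor, a higher number a weaker inhibitor), compound 2 gives 3000000 nM, the only number recorded for the set. Among the measured compounds shown here, compound 1, `CCOC(=O)/C=C/C[C@H](CCC(=O)N(C)C)NC(=O)[C@H](CC(C)C)NC(=O)[C@@H](NC(=O)[C@H](C)NC(=O)[C@H](CO)NC(C)=O)C(C)C`, differs more widely from compound 2, including a replacement of the terminal aldehyde, and in this assay compound 1 gives "not active" (no number reported), with no figure attached, so it sets no scale for a step.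

Compound 3, `CC(=O)N[C@@H](CO)C(=O)N[C@@H](C)C(=O)N[C@H](C(=O)N[C@@H](CC(C)C)C(=O)N[C@H](C=O)CC1CCCCC1)C(C)C`, is compound 2 with one change: cyclohexyl in place of isopropyl on a saturated chain carbon, two bonds along the chain from an amide-type nitrogen and a carbonyl carbon. For the measured compounds named here, no pair of measured compounds in the set covers this change, so the size of its step is uncertain. A gain beyond the scatter is expected for compound 3, with the step from compound 2 to compound 3 estimated as a 3.0-fold lower number from compound 2 to compound 3 (0.48 log units; beyond the scatter). In this assay compound 3 is therefore expected to give about 1000000 nM, with the range 200000 nM to 5000000 nM. Given that compound 2 gives 3000000 nM, a weak outcome for compound 3 cannot be excluded.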

Compound 3, half-maximal inhibitory concentration: 62000 nM
Estimate against measurement, compound 3: 16-fold (1.21 log units) above, and the stated range ends above it.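

In this assay, among these compounds, the saturated chain carbon two bonds along the chain from an amide-type nitrogen and a carbonyl carbon proves sensitive to the group it carries: cyclohexyl in place of isopropyl gives a 48-fold lower number from compound 2 to compound 3 (1.68 log units; beyond the scatter), the first step that can be read, and it is a large one. The entering group is all carbon, with one six-membered non-aromatic ring, and neither group has hydrogen-bond donors, hydrogen-bond acceptors or a net charge, so the step comes with a change in carbon count and ring content alone. Nothing available here accounts for the size of this step.

As far as these compounds go, whether the gain depends on the ring itself or simply on the larger number of carbons stays open; a phenyl ring, a cyclopentyl ring or a longer straight chain at this place would separate the two readings. From the compounds shown here alone, compound 1 differs from compound 2 in more than one place, so the role of the terminal aldehyde, and whether the cyclohexyl step carries over to another chain end, also stay open.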